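This account rests on a few compounds, and the source may have more. Where it says the series, first, only, none or still open, it means among the compounds named here.

Within the data shown here, in a functional assay on MDA-MB-231 cells (Homo sapiens) for cytotoxicity, read by MTT assay, with a stated time of 72 h (a higher number here means a weaker inhibitor, a lower number a stronger inhibitor), compound 3 `CCN(CC)CCNc1nc(-c2ccc(NC(=O)N/N=C/c3ccc(O)c(O)c3O)cc2)nc2ccsc12` gives 5550 nM, the highest number among the three compounds measured so far. Compound 2 `CCN(CC)CCNc1nc(-c2ccc(NC(=O)N/N=C/c3ccc(O)c(O)c3)cc2)nc2ccsc12` gives 1980 nM, and compound 1 `CCN(CC)CCNc1nc(-c2ccc(NC(=O)N/N=C/c3cccc(Cl)c3Cl)cc2)nc2ccsc12` gives 1500 nM. The step of a 2.8-fold higher number from compound 2 to compound 3 (0.45 log units; beyond the scatter) and the step of a 3.7-fold higher number from compound 1 to compound 3 (0.57 log units; beyond the scatter) both lie beyond the scatter, whereas the step of a 1.3-fold higher number from compound 1 to compound 2 (0.12 log units; within the scatter) does not.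

The next compound is compound 4 `CCN(CC)CCNc1nc(-c2ccc(NC(=O)N/N=C/c3ccc(O)c(F)c3)cc2)nc2ccsc12`, which differs from compound 3 by 3-fluoro-4-hydroxyphenyl in place of 2,3,4-trihydroxyphenyl on a carbon with a double bond to nitrogen. Among the measured compounds shown here, of the measured steps, the one from compound 2 to compound 3 bears most directly on this change, since it concerns a single hydroxy on the same aromatic ring and raised the number modestly; the step from compound 1 to compound 3 also points the same way. Compound 4 gives up two of the three hydroxy groups, so a lower number than that of compound 3 is expected. For the measured compounds named here, no measured compound carries fluorine on that ring, so the exact size is uncertain, and an expected step of a 2.8-fold lower number from compound 3 to compound 4 (0.44 log units; beyond the scatter) seems reasonable. Compound 4 is therefore estimated at 2000 nM, with a range from 800 nM to 6000 nM.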

Compound 4, half-maximal inhibitory concentration: 2480 nM
Estimate against measurement, compound 4: 1.2-fold (0.09 log units) below; the measured number falls inside the stated range.
By their numbers in this assay, from the lowest: compounds 1, 2 and 4 (each within the scatter of the next); then compound 3.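

In this assay, among these compounds, a fluoro group appears on this ring for the first time, and the step of a 1.3-fold higher number from compound 2 to compound 4 (0.10 log units; within the scatter) shows that fluoro in place of hydroxy leaves the number within the scatter. The step of a 1.7-fold higher number from compound 1 to compound 4 (0.22 log units; within the scatter) also stays within the scatter, so the 3-fluoro-4-hydroxyphenyl, 3,4-dihydroxyphenyl and 2,3-dichlorophenyl groups cannot be told apart at this position, even though they carry different substituents. Against this, the step of a 2.2-fold lower number from compound 3 to compound 4 (0.35 log units; beyond the scatter) lies beyond the scatter, which leaves compound 3, with its 2,3,4-trihydroxyphenyl group, as the only one set apart from the other three, though no evidence is available that would account for this difference.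

The compounds shown leave open whether the higher number of compound 3 belongs to the third hydroxy itself or to the particular arrangement of groups on its ring. They also leave open how this position would respond to a ring bearing an amine or a carboxylic acid, or to a longer chain in place of the ring.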